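A few compounds are considered here, and "the series" means these few. Any claim that something is new, unique, unknown or untested is made for them only; others in the source may bear on it.

Working notes on the series. The shared core of compound 1 `COc1ccc(C(=O)c2cc(OC)c(OC)c(OC)c2)cc1NC(=O)/C=C/c1cc(OC)c(OC)c(OC)c1` carries a cinnamamide whose aryl end is varied; in a functional assay on DU-145 cells (Homo sapiens) for cytotoxicity, read by MTT assay, with a stated time of 72 h (a higher number here means a weaker inhibitor, a lower number a stronger inhibitor), compound 1 gives 6300 nM. Compound 2 `C#CCOc1cccc(/C=C/C(=O)Nc2cc(C(=O)c3cc(OC)c(OC)c(OC)c3)ccc2OC)c1` gives 15800 nM in this assay, and compound 3 `COc1ccc(C(=O)c2cc(OC)c(OC)c(OC)c2)cc1NC(=O)/C=C/c1ccc(F)c(F)c1` gives 10200 nM. Compound 3 thus sits second highest of the three numbers, nearest compound 2 and furthest from compound 1, with both gaps within the scatter.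

Compound 4 `COc1ccc(C(=O)c2cc(OC)c(OC)c(OC)c2)cc1NC(=O)/C=C/c1ccc(N)cc1` is not yet measured. Its change from compound 3 is 4-aminophenyl in place of 3,4-difluorophenyl on a double-bonded chain carbon bound to a double-bonded chain carbon.

All measured steps swap the aryl at this same place: a 2.5-fold higher number from compound 1 to compound 2 (0.40 log units; beyond the scatter), a 1.6-fold higher number from compound 1 to compound 3 (0.21 log units; within the scatter), and a 1.5-fold lower number from compound 2 to compound 3 (0.19 log units; within the scatter). Only one of the three moved beyond the scatter, and that one modestly. A small step in this assay is therefore expected, direction uncertain, most likely none beyond the scatter.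

Compound 4 is expected to give 8000 nM with a range of 3000 nM to 25000 nM. The expected step is a 1.3-fold lower number from compound 3 to compound 4 (0.11 log units; within the scatter).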

Compound 4, half-maximal inhibitory concentration: 13500 nM
Estimate against measurement, compound 4: 1.7-fold (0.23 log units) below; measured number inside the range.
By their numbers in this assay, from the lowest: compounds 1, 3, 4 and 2 (each within the scatter of the next, the first and the last beyond it).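

In (this assay), 4-aminophenyl brings a hydrogen-bond donor to this place, where 3,4-difluorophenyl has none, yet the number stays within the scatter of the 3,4-difluorophenyl compound (a 1.3-fold higher number from compound 3 to compound 4 (0.12 log units; within the scatter)) and of the 3-(propargyloxy)phenyl compound (a 1.2-fold lower number from compound 2 to compound 4 (0.07 log units; within the scatter)). The 3,4,5-trimethoxyphenyl compound now has a second step beyond the scatter, though a modest one (a 2.1-fold higher number from compound 1 to compound 4 (0.33 log units; beyond the scatter)), so compounds 2 and 4 both sit apart from compound 1, while compound 3 goes against a clean split by lying within the scatter of all three others. No measurement at hand bears on the reason for these steps.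

The compounds shown leave open whether a carboxylic acid or a nitrile on this phenyl ring would move the number beyond the scatter in either direction. They also leave open whether a longer chain between the amide and the aryl would do so.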